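The compounds below may be only part of what the source reports. "The series", "measured", "known", "first", "only" and "open" are said of these compounds alone.

Measured so far:
compound 1 `Cc1cc(C)c(S(=O)(=O)N2CCC(C3OCC(C)CO3)CC2)c(C)c1` gives > 5000 nM
compound 2 `Cc1noc(C)c1S(=O)(=O)N1CCC(N2CCC(C)CC2)CC1` gives > 5000 nM
compound 3 `CC1CCN(C2CCN(S(=O)(=O)c3ccc(C(C)C)cc3)CC2)CC1` gives 685 nM

All three were tested in a functional assay on DLD-1 cells (Homo sapiens) for antiproliferative activity, read by CellTiter-Glo, with a stated time of 72 h; a higher number here means a weaker inhibitor, a lower number a stronger inhibitor. Compound 1 returns > 5000 nM, which is a limit of the assay rather than a number. Compound 2 likewise returns > 5000 nM, again a limit and not a number. Compound 3 gives 685 nM. Compound 2 therefore stands at the limit of > 5000 nM in this assay, at which 2 of the 3 values shown sit. Among the measured compounds shown here, no pair among the three differs in only one place, so no measured step is available.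

Compound 4 `CC1CCN(C2CCN(S(=O)(=O)c3nccn3C)CC2)CC1` differs from compound 2 in one place: 1-methyl-1H-imidazol-2-yl in place of 3,5-dimethyl-1,2-oxazol-4-yl on a sulfonyl sulfur. Without a measured step of this kind to lean on, the expectation in this assay is a step of no clear size in either direction. Compound 4 is estimated at 5000 nM, within 1500 nM to 20000 nM. This amounts to an expected step of a number no higher from compound 2 to compound 4 (the limit leaves the size open).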

Compound 4, half-maximal inhibitory concentration: > 5000 nM
Compound 4: a limit, no number (the forecaster's own chance of this, stated with the estimate: 60%); the middle value lies on the limit itself.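

Among the compounds shown here, compound 2 and compound 4 both return a limit rather than a number, so no step between them can be read. As far as these compounds go, whether 1-methyl-1H-imidazol-2-yl and 3,5-dimethyl-1,2-oxazol-4-yl differ in activity on this sulfonyl sulfur remains open.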